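Third Methoxy on the Benzoate Ring of Compound 2

The source may hold more compounds than are shown below. What is called first, only, known or untested is meant among the compounds shown, and "the series" means these compounds.

Measured so far:
compound 1, `COC(=O)/C(=C\c1ccc(OC(=O)c2ccc(OC)cc2)cc1)Sc1ccnc2cc(Cl)ccc12`: 9090 nM
compound 2, `COC(=O)/C(=C\c1ccc(OC(=O)c2ccc(OC)c(OC)c2)cc1)Sc1ccnc2cc(Cl)ccc12`: 5290 nM

In a functional assay on HL-60 cells (Homo sapiens) for cytotoxicity, read by MTT assay, with a stated time of 24 h (on this read-out higher numbers stand for weaker inhibition and lower numbers for stronger inhibition), compound 1 gives 9090 nM and compound 2 gives 5290 nM. Compound 2 has the lowest of the two numbers, but the gap to compound 1, a 1.7-fold lower number from compound 1 to compound 2 (0.24 log units; within the scatter), lies within the scatter, so no order between them can be claimed.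

Compound 3, `COC(=O)/C(=C\c1ccc(OC(=O)c2cc(OC)c(OC)cc2OC)cc1)Sc1ccnc2cc(Cl)ccc12`, carries one further change: methoxy in place of hydrogen on an aromatic carbon. Within the data shown here, the only measured step that bears on this, a methoxy added to the same benzoate ring in going from compound 1 to compound 2, gave a 1.7-fold lower number from compound 1 to compound 2 (0.24 log units; within the scatter). A similar addition is therefore expected to move the number little, if at all, beyond the scatter, in either direction.

The estimate for compound 3 in this assay is 4500 nM, within 2000 nM to 10000 nM, a step of a 1.2-fold lower number from compound 2 to compound 3 (0.07 log units; within the scatter) expected from compound 2.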

Compound 3, half-maximal inhibitory concentration: 6260 nM
Estimate against measurement, compound 3: 1.4-fold (0.14 log units) below; the measured number falls inside the stated range.
By their numbers in this assay, from the lowest: compounds 2, 3 and 1 (each within the scatter of the next).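

In this assay, a methoxy on the aromatic carbon ortho to a large group, para to one methoxy group and meta to another gives a 1.2-fold higher number from compound 2 to compound 3 (0.07 log units; within the scatter) and so brings no readable change, which shows that this position, bare in compound 1 and compound 2, accepts the group without a shift beyond the scatter. The whole replacement of 4-methoxyphenyl by 2,4,5-trimethoxyphenyl gives a 1.5-fold lower number from compound 1 to compound 3 (0.16 log units; within the scatter) and also stays within the scatter, so the larger change on this ring is no more readable than the single additions. Nothing available explains this flat result.

The compounds shown leave open whether anything other than methoxy at this position, such as an amine or a carboxylic acid, would move the number beyond the scatter. They also leave open whether a longer chain in place of the methyl ester would do so.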